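Removing the ethynyl from the core of compound 1

The source may report more compounds than this note shows. Statements on the series, on what has been measured and on what is new or still open speak of the compounds shown alone.

Going by the values given here, compound 1 `C#Cc1nccn1C#Cc1ccccc1` and compound 2 `C#Cc1nc(-c2ccc(F)cc2)cn1C#C` are the two measured members. In a functional assay on A549 cells (Homo sapiens) for cytotoxicity, read by resazurin assay, with a stated time of 72 h (on this read-out higher numbers stand for weaker inhibition and lower numbers for stronger inhibition), compound 1 gives 5000 nM, the highest of the two numbers; in this assay compound 2 gives 2600 nM, within the scatter of compound 1, so the pair shows no order. Compound 3 `C(#Cn1ccnc1)c1ccccc1` differs from compound 1 by hydrogen in place of ethynyl on an aromatic carbon between two ring nitrogen atoms. Among the compounds with values here, no step among the measured compounds covers this change. The step of a 1.6-fold higher number from compound 1 to compound 3 (0.20 log units; within the scatter) is expected to be small, toward a higher number if anything, and may not exceed the scatter. Compound 3 is expected at 8000 nM, from 3000 nM to 25000 nM.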

Compound 3, half-maximal inhibitory concentration: 9200 nM
The estimate for compound 3 lay 1.2-fold (0.06 log units) below the measured number; measured number inside the range.
By their numbers in this assay, from the lowest: compounds 2, 1 and 3 (each within the scatter of the next, the first and the last beyond it).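

In this assay, hydrogen in place of ethynyl on the aromatic carbon between two ring nitrogen atoms gives a 1.8-fold higher number from compound 1 to compound 3 (0.26 log units; within the scatter). Going by these compounds alone, this is the first direct reading of this position: losing the ethynyl there leaves the value within the scatter, so this series does not depend on that group at the level this assay resolves. Nothing measured bears on the reason for this.

Going by these compounds, whether an amine or a carboxylic acid at this position would give a step beyond the scatter remains open. So does whether the same exchange on compound 2 would give a similar step.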